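Chlorine-to-amine exchange on two benzylated purine cores

This account rests on a few compounds, and the source may have more. Where it says the series, first, only, none or still open, it means among the compounds named here.

Three compounds were measured in a functional assay on HCT-15 cells (Homo sapiens) for cytotoxicity, read by sulforhodamine B assay, with a stated time of 48 h; on this read-out higher numbers stand for weaker inhibition of growth and lower numbers for stronger inhibition of growth. Compound 1 `ClCc1ccccc1Cn1cnc2c(Cl)nc(Cl)nc21` gives 330 nM. Compound 3 `Nc1nc(Cl)c2ncn(Cc3ccccc3CCl)c2n1` gives 2700 nM; the change from compound 1 to compound 3, (amino in place of chloro on an aromatic carbon), brought an 8.2-fold higher number from compound 1 to compound 3 (0.91 log units; beyond the scatter). Compound 2 `ClCc1cccc(Cn2cnc3c(Cl)nc(Cl)nc32)c1` gives 2390 nM; it has the same atoms as compound 1 joined differently, and the difference between the two cores is not broken down here. Compound 4 `Nc1nc(Cl)c2ncn(Cc3cccc(CCl)c3)c2n1` is not yet measured in this assay. Its difference from compound 2 is amino in place of chloro on an aromatic carbon, the same change as that from compound 1 to compound 3, at the same place. Because compound 1 showed an 8.2-fold higher number from compound 1 to compound 3 (0.91 log units; beyond the scatter) on this change, a step of a 5.0-fold higher number from compound 2 to compound 4 (0.70 log units; beyond the scatter) is expected, weaker growth inhibition starting from compound 2. Compound 4 is therefore estimated at 12000 nM, with a likely range from 4000 nM to 40000 nM.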

Compound 4, concentration for 50% growth inhibition: 2510 nM
Beside the measured number, compound 4's estimate is 4.8-fold (0.68 log units) above it; the measured number lies below the stated range.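

In this assay, amino in place of chloro on an aromatic carbon gave a 1.1-fold higher number from compound 2 to compound 4 (0.02 log units; within the scatter), and the step seen on the other core did not carry over: the same change on two cores in this assay, an 8.2-fold higher number (0.91 log units; beyond the scatter) from compound 1 to compound 3 and a 1.1-fold higher number (0.02 log units; within the scatter) from compound 2 to compound 4, 7.8-fold (0.89 log units) apart, beyond the scatter of two such steps. In this pair of cores, then, the size of the step depends on the core, and a step read on one core is no safe guide to its size on the other. Two pairs do not show why the steps differ, nor which of them a further core would follow.

The compounds shown leave open whether another group in that place, such as a dimethylamino or a methoxy group, would also differ between the two cores. Also open, as far as these compounds go, is whether a hydroxymethyl group in place of the chloromethyl group would alter either step.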